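Swapping a Phenoxy Linker for a Benzyl Chain

The source may hold more compounds than are shown below. What is called first, only, known or untested is meant among the compounds shown, and "the series" means these compounds.

Compound 3 `CC(C)C[C@H](N)c1cc(C(F)(F)F)ccc1N1CCN(C(=O)COc2cccc(Cl)c2)CC1` shares its core with compound 2 `CC(C)C[C@H](N)c1cc(C(F)(F)F)ccc1N1CCN(C(=O)COc2ccc([N+](=O)[O-])cc2)CC1` and compound 1 `CC(C)C[C@H](N)c1cc(C(F)(F)F)ccc1N1CCN(C(=O)C(C)Cc2ccc(Cl)c(Cl)c2)CC1`. In an assay on HEK293 cells for displacement of a labelled ligand from Melanocortin receptor 4 (Homo sapiens) (on this read-out lower numbers stand for stronger inhibition and higher numbers for weaker inhibition), compound 3 gives 2600 nM, the lower of the two single numbers, while compound 2 gives 3100 nM; the step of a 1.2-fold lower number from compound 2 to compound 3 (0.08 log units; within the scatter) stays within the scatter. Compound 1 has two entries, 120 nM; 1600 nM (2 entries). Compound 4 `Cc1cc(CC(C)C(=O)N2CCN(c3ccc(C(F)(F)F)cc3[C@@H](N)CC(C)C)CC2)ccc1Cl` changes compound 3 at the amide: 1-(4-chloro-3-methylbenzyl)ethyl in place of (3-chlorophenoxy)methyl on a carbonyl carbon. Among the compounds with values here, no single-place step covers this exchange, but the two entries of compound 1 (the several entries of compound 1 in this assay, 120 nM; 1600 nM (2 entries)), which carries a similar chain ending in a dichlorophenyl, include one far lower than the value of compound 3, so a move toward a lower number is expected in this assay. Compound 4 is therefore estimated at 400 nM (range 100 nM to 2000 nM), an expected step of a 6.5-fold lower number from compound 3 to compound 4 (0.81 log units; beyond the scatter).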

Compound 4, inhibition constant: 71 nM
The estimate for compound 4 lay 5.6-fold (0.75 log units) above the measured number; measured number below the stated range.
By their numbers in this assay, from the lowest: compound 4; then compounds 3 and 2 (each within the scatter of the next).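

Moving from either phenoxy compound to the 1-(4-chloro-3-methylbenzyl)ethyl chain on the carbonyl carbon strengthens inhibition in this assay, with a 37-fold lower number from compound 3 to compound 4 (1.56 log units; beyond the scatter) and a 44-fold lower number from compound 2 to compound 4 (1.64 log units; beyond the scatter). The earlier change of ring groups within the phenoxy series, a 1.2-fold lower number from compound 2 to compound 3 (0.08 log units; within the scatter), gave no such separation. This position therefore responds strongly to a change of the whole chain, and not to every change made there.

As far as these compounds go, the oxygen, the chain branch and the ring groups all change together, so their separate contributions remain open. Also open, from the compounds shown here alone, is how an amine or a carboxylic acid on this chain would fare.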